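Sulfonamide series: methoxy added on the aryl sulfonyl ring

The source may hold more compounds than are shown below. What is called first, only, known or untested is meant among the compounds shown, and "the series" means these compounds.

Measured so far in an assay on HEK293 cells for displacement of a labelled ligand from 5-hydroxytryptamine receptor 6 (Homo sapiens), with a stated time of 60 min, tested at 0.01 uM, in the presence of a further agent that is not named here; a higher number here means a stronger effect of the compound at the concentration tested, a lower number a weaker effect:
compound 1 `COc1ccc(S(=O)(=O)NCCN2CCC(CCC(=O)c3cc(Cl)c(N)cc3OC)CC2)cc1Cl` gives 20%
compound 2 `COc1cc(N)c(Cl)cc1C(=O)CCC1CCN(CCNS(=O)(=O)c2cc(Br)c(N)c(Br)c2)CC1` gives 52%
compound 3 `COc1ccc(S(=O)(=O)NCCN2CCC(CCC(=O)c3cc(Cl)c(N)cc3OC)CC2)cc1` gives 36%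

Compound 3 stands second highest of the three numbers in this assay. Its nearest neighbour is compound 1, with a number 16 percentage points higher from compound 1 to compound 3 (beyond the scatter); the furthest is compound 2, with a number 16 percentage points lower from compound 2 to compound 3 (beyond the scatter). The largest step in the set is a number 32 percentage points higher from compound 1 to compound 2 (beyond the scatter).

Compound 4 `COc1ccc(S(=O)(=O)NCCN2CCC(CCC(=O)c3cc(Cl)c(N)cc3OC)CC2)cc1OC` is the next member. The change from compound 3 is methoxy in place of hydrogen on an aromatic carbon.

Within the data shown here, only one measured step touches the same aromatic carbon: a number 16 percentage points higher from compound 1 to compound 3 (beyond the scatter), where chloro was replaced by hydrogen. The other two steps exchange the whole aryl group on the sulfonyl sulfur and give no reading on a single methoxy entering. Among the measured compounds shown here, no measured pair shows hydrogen giving way to methoxy, so the direction is open. Given that the one substituent seen on this carbon, chloro in compound 1, went with the lower number in a number 16 percentage points higher from compound 1 to compound 3 (beyond the scatter), a small drop is the more likely outcome, but a step within the scatter is expected as the central case.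

Compound 4 is therefore estimated at 32% in this assay, with a range of 18% to 50%, which means an expected step of a number 4 percentage points lower from compound 3 to compound 4 (within the scatter).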

Compound 4, a percentage reported as inhibition, at one concentration (the size of the read-out at that concentration, not a potency): 3%
For compound 4 the middle estimate is 29 percentage points above the measured one; measured number outside the range, below it.
By their numbers in this assay, from the lowest: compound 4; then compound 1; then compound 3; then compound 2.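

In this assay, among these compounds, methoxy entering this aromatic carbon, ortho to a methoxy group, gives a large loss (a number 33 percentage points lower from compound 3 to compound 4 (beyond the scatter)), the first reading of a group added where compound 3 carries hydrogen. Methoxy also falls short of chloro on the same carbon (a number 17 percentage points lower from compound 1 to compound 4 (beyond the scatter)), so among the three groups seen here, the order from the highest number is hydrogen, chloro, methoxy, and 3,4-dimethoxyphenyl stands well short of 4-amino-3,5-dibromophenyl (a number 49 percentage points lower from compound 2 to compound 4 (beyond the scatter)), leaving compound 4 the lowest of the four compounds. No measurement at hand explains why this carbon responds in this way.

The compounds shown leave open whether a fluoro or hydroxyl group on this carbon would stay near compound 3 or fall towards compound 4, and so whether any replacement for hydrogen here can be tolerated. Among the compounds shown here, they also leave open whether a methoxy at this carbon would give a loss of similar size on a different aryl group on the sulfonyl sulfur, since this change is seen only on the 4-methoxyphenyl compound.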